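Adding one fluoro to compound 2

The source may report more compounds than this note shows. Statements on the series, on what has been measured and on what is new or still open speak of the compounds shown alone.

Measured so far in a physicochemical assay for solubility, at pH 7.4; on this read-out higher numbers stand for higher solubility and lower numbers for lower solubility
Compound 1 `CCOC(=O)c1c(-c2cccc(OC)c2)[nH]c2cc(OC)ccc2c1=O` gives 74000 nM
Compound 2 `CCOC(=O)c1c(-c2cccc(Oc3ccccc3)c2)[nH]c2cc(OC)ccc2c1=O` gives 4300 nM

Of these two, compound 2 stands lowest, with 4300 nM as the smaller number. Compound 3 `CCOC(=O)c1c(-c2cccc(Oc3ccccc3)c2)[nH]c2cc(OC)c(F)cc2c1=O` keeps all of compound 2 except for one change: fluoro in place of hydrogen on an aromatic carbon on the shared core. Among the compounds with values here, no measured step tests a fluoro. Within the data shown here, the only step available is a 17-fold lower number from compound 1 to compound 2 (1.24 log units; beyond the scatter) for phenyl in place of methyl on an oxygen on an aromatic ring. That step is large, but it involves a different place and a far bigger swap, so it offers little guidance for a single fluoro. In this assay no step beyond the scatter is therefore expected. For compound 3 the estimated value is 3800 nM (expected range 1500 nM to 8500 nM) in this read-out. This expectation amounts to a 1.1-fold lower number from compound 2 to compound 3 (0.05 log units; within the scatter) as an estimated step.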

Compound 3, solubility: 4300 nM
Estimate against measurement, compound 3: 1.1-fold (0.05 log units) below; the range from low to high includes it.
By their numbers in this assay, from the lowest: compounds 2 and 3 (each within the scatter of the next); then compound 1.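

In this assay, within the data shown here, the earlier compounds tested only a swap on an oxygen on an aromatic ring, while compound 3 changes the shared core itself. Fluoro in place of hydrogen on this aromatic carbon, ortho to a methoxy group, gives no change at the digits printed from compound 2 to compound 3 (within the scatter), so this position takes a fluoro without a step beyond the scatter, at least on compound 2. No measurement at hand offers a reason for this result.

As far as these compounds go, whether the same holds for other groups on this carbon, such as chloro, an amine or a carboxylic acid, remains open. Also open, from the compounds shown here alone, is whether fluoro here would behave the same way on compound 1, which carries methyl rather than phenyl on that oxygen.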